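Compound 3 to compound 4: cyclopentylsulfanyl to hexyloxy

The source may hold more compounds than are shown below. What is called first, only, known or untested is meant among the compounds shown, and "the series" means these compounds.

Measured in an ADME assay on HFF cells (Homo sapiens) for cytotoxicity, with a stated time of 8 days; a higher number here means that more compound is tolerated, a lower number that less compound is tolerated:
- compound 1 `Nc1nc(OCc2ccccc2)c2ncn(/C=C3/CC3(CO)CO)c2n1` gives > 300000 nM (a limit)
- compound 2 `Nc1nc(NC2CCCC2)c2ncn(/C=C3/CC3(CO)CO)c2n1` gives > 300000 nM (a limit)
- compound 3 `Nc1nc(SC2CCCC2)c2ncn(/C=C3/CC3(CO)CO)c2n1` gives > 300000 nM (a limit)

Compound 3 has no number in this assay, only a limit, and it shares that position with the other two compounds (the limit of > 300000 nM in this assay, at which 3 of the 3 values shown sit).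

The next compound is compound 4 `CCCCCCOc1nc(N)nc2c1ncn2/C=C1/CC1(CO)CO`, not yet measured. The change is hexyloxy in place of cyclopentylsulfanyl on an aromatic carbon, next to the ring nitrogen (hexyloxy in place of cyclopentylsulfanyl on an aromatic carbon).

Going by the values given here, three measured steps concern this same carbon: a step that the two limits leave unreadable from compound 1 to compound 2, a step that the two limits leave unreadable from compound 1 to compound 3 and a step that the two limits leave unreadable from compound 2 to compound 3. None of them has a readable size. Among the compounds with values here, they show only that benzyloxy, cyclopentylamino and cyclopentylsulfanyl all end at the same limit, and no compound among the three goes against this. None of the three carries an open chain at this carbon, so the step to hexyloxy rests on indirect support.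

No step beyond the scatter is expected in this assay, and a reported limit is the likeliest outcome, though a measured number on the lower side remains possible. The expected step is a number no higher from compound 3 to compound 4 (the limit leaves the size open). For compound 4 the estimate is 300000 nM, with an expected range from 100000 nM to 600000 nM.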

Compound 4, half-maximal cytotoxic concentration: > 200000 nM
Compound 4: a limit, no number; the forecaster's own chance of this, stated with the estimate: 70%; the middle value does not contradict the limit.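

In this assay compound 4 gives > 200000 nM, which is a limit and not a number. The steps to compound 4 from compound 1, compound 2 and compound 3 cannot be read: all four values are limits. The compounds shown leave open whether benzyloxy, cyclopentylamino, cyclopentylsulfanyl and hexyloxy differ at all in this assay, and at what concentration any of these compounds reaches the half-maximal read-out.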